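Halogen swap on the carboxamide ring of two anilide acetamides

The compounds below may be only part of what the source reports. "The series", "measured", "known", "first", "only" and "open" are said of these compounds alone.

The measured compounds:
compound 1, `Cc1ccc(OCC(=O)Nc2ccc(Cl)cc2C(N)=O)cc1`, 24.1%
compound 2, `NC(=O)c1cc(Cl)ccc1NC(=O)COc1ccc(Cl)cc1Cl`, 18.8%
compound 3, `Cc1ccc(OCC(=O)Nc2ccc(I)cc2C(N)=O)cc1`, 49.8%

All three were tested in a functional assay on K562 cells (Homo sapiens) for inhibition, read by trypan blue exclusion, with a stated time of 24 h, tested at 10 uM; a lower number here means less inhibition of growth, a higher number more inhibition of growth at the concentration tested. Compound 1 gives 24.1% in this assay, and compound 3 gives 49.8%. The two share a core and differ in one place: iodo in place of chloro on an aromatic carbon. This change produced a number 25.7 percentage points higher from compound 1 to compound 3 (beyond the scatter).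

Compound 2, with 18.8% in this assay, has the lowest of the three numbers, though it stands within the scatter of compound 1. The difference between the core of compound 2 and the core of compound 1 is not broken down here.

Compound 4, `NC(=O)c1cc(I)ccc1NC(=O)COc1ccc(Cl)cc1Cl`, has not yet been measured in this assay. It is related to compound 2 by the same change that turns compound 1 into compound 3: iodo in place of chloro on an aromatic carbon. The place lines of the two changes agree word for word, so this is the same change on a different core.

Resting on the step of the one earlier pair, the same kind of increase is expected from compound 2 to compound 4, namely a number 25.2 percentage points higher from compound 2 to compound 4 (beyond the scatter), because the only precedent is a number 25.7 percentage points higher from compound 1 to compound 3 (beyond the scatter). For the measured compounds named here, only one earlier pair supports this, so the range is kept wide. Compound 4 is therefore estimated at 44% in this assay, expected to lie between 28% and 60%.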

Compound 4, percent growth inhibition at one concentration: 74.7%
Beside the measured number, compound 4's estimate is 30.7 percentage points below it, outside the stated range (above it).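

In this assay the same exchange of chloro for iodo, on an aromatic carbon meta to a carbamoyl group, gave a number 55.9 percentage points higher from compound 2 to compound 4 (beyond the scatter) and so raised the number on both cores, but the two steps differ in size: the same change on two cores in this assay, a number 25.7 percentage points higher (beyond the scatter) from compound 1 to compound 3 and a number 55.9 percentage points higher (beyond the scatter) from compound 2 to compound 4, 30.2 percentage points apart, beyond the scatter of two such steps.
Across these two pairs, then, the direction of the change carried from one core to the other while its size did not, so a step read on one core served here as a guide to the sign and not to the amount.
The two pairs do not show which feature of the cores sets the size of the step, and they establish no rule for any core beyond these two.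

The compounds shown carry only chloro or iodo at this place, which leaves open how bromo, fluoro or a plain hydrogen there would compare, and whether the step would survive with a carboxylic acid or a nitrile in place of the carbamoyl group. They also leave open how the two cores would respond to an amine or a longer chain on the aromatic ring at the far end of the ether link.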